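This account rests on a few compounds, and the source may have more. Where it says the series, first, only, none or still open, it means among the compounds named here.

Measured so far in a physicochemical assay for solubility, read by HPLC, using the shake flask method, measured as kinetic solubility, with a stated time of 2 h, at pH 7.4; a higher number here means a more soluble compound, a lower number a less soluble compound:
- compound 1, `Cc1cc(Nc2ccccn2)n2nc(C)c(-c3ccccc3)c2n1`: < 5000 nM, a limit of the assay, not a number
- compound 2, `Cc1cc(NCc2ccccn2)n2ncc(-c3ccc(F)c(Cl)c3)c2n1`: < 5000 nM, a limit of the assay, not a number

Both measured compounds sit at the same limit, and nothing about their order can be drawn from this. Going by the values given here, compound 2 stands at a limit only; there is no numerical value for it, and the one further value shown, that of compound 1, is a limit as well. The evidence on the measured set is therefore confined to the limit of < 5000 nM in this assay, at which 2 of the 2 values shown sit.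

Compound 3 is `Cc1cc(NCc2ccccn2)n2ncc(C3=CCC(F)(F)CC3)c2n1`. Compared with compound 2 the change is 4,4-difluorocyclohex-1-en-1-yl in place of 3-chloro-4-fluorophenyl on an aromatic carbon. Among the compounds with values here, no step between measured compounds is available to calibrate this change, so any expectation rests on the shared core and the two limits alone.

It is estimated that the step from compound 2 to compound 3, a step that the limit leaves unreadable from compound 2 to compound 3, will be none beyond the usual scatter, since the measured set offers no direction. For compound 3 the expected solubility in this assay is 3000 nM, with a range from 800 nM to 12000 nM, and a real chance that only a limit is reported again.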

Compound 3, solubility: 5000 nM
Estimate against measurement, compound 3: 1.7-fold (0.22 log units) below; low and high end bracket the measured number.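

In this assay, 4,4-difluorocyclohex-1-en-1-yl in place of 3-chloro-4-fluorophenyl, on an aromatic carbon of the five-membered aromatic ring, gives a number no lower from compound 2 to compound 3 (the limit leaves the size open); only the direction can be taken from this step. Compound 3 gives 5000 nM, the only number among the compounds shown, so this position carries a six-membered non-aromatic ring of carbon only and the series still yields a reading rather than a limit. The other two compounds remain at a limit, which still bounds what can be said of the measured set: the limit of < 5000 nM in this assay, at which 2 of the 3 values shown sit.

The compounds shown do not separate the loss of the aromatic ring from the exchange of chlorine for a second fluorine, as both changes fall within the one step, and the size of that step remains open. Also open, as far as these compounds go, is how this assay would read with a simple amine, a carboxylic acid or a longer chain on this same aromatic carbon, and whether any such group would move the series clearly away from the limit.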